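The source may report more compounds than this note shows. Statements on the series, on what has been measured and on what is new or still open speak of the compounds shown alone.

Measured so far in a functional assay on HCT-116 cells (Homo sapiens) for inhibition, read by CCK-8 assay, with a stated time of 72 h, tested at 2 uM (a higher number here means more inhibition of growth at the concentration tested, a lower number less inhibition of growth), for this series
- compound 1 `Nc1ccccc1NC(=O)/C=C/c1ccc(CSc2cccc(F)c2)cc1` gives 7.95%
- compound 2 `Cc1ccc(SCc2ccc(C(=O)Nc3ccccc3N)cc2)cc1` gives 74.8%
- compound 3 `CC(C)(C)c1ccc(SCc2ccc(C(=O)Nc3ccccc3N)cc2)cc1` gives 4.81%

Compound 2 holds the highest of the three numbers, and both gaps to the others lie beyond the scatter. Compound 4 `Cc1cc(C)cc(SCc2ccc(C(=O)Nc3ccccc3N)cc2)c1` carries the change 3,5-dimethylphenyl in place of 4-methylphenyl on a sulfur with 3,5-dimethylphenyl in place of 4-methylphenyl on a sulfur. Going by the values given here, compound 1 differs from compound 2 in more than one place and gives no clean step. Among the compounds with values here, the only measured step on that group is a number 70 percentage points lower from compound 2 to compound 3 (beyond the scatter) and it is large, while the change to compound 4 is smaller, so a moderate fall is expected in this assay with wide uncertainty. The estimated move is a number 29.8 percentage points lower from compound 2 to compound 4 (beyond the scatter) as a working figure. For compound 4 the estimate is 45% with an expected range from 15% to 80% as the working span.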

Compound 4, percent growth inhibition at one concentration: 3.22%
For compound 4 the middle estimate is 41.8 percentage points above the measured one, outside the stated range (below it).
By their numbers in this assay, from the lowest: compounds 4, 3 and 1 (each within the scatter of the next); then compound 2.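

On the aryl group at this sulfur, the high number of compound 2 in this assay does not survive even a modest change: 3,5-dimethylphenyl in place of 4-methylphenyl gives a number 71.6 percentage points lower from compound 2 to compound 4 (beyond the scatter) and is large. The earlier tert-butyl step therefore did not mark out bulky replacements alone, since compound 4 lies within the scatter of compound 3. Going by these compounds, whether the second methyl or the loss of the methyl from the 4-position matters remains open, as do 3-methylphenyl, unsubstituted phenyl and 4-methoxyphenyl at this place. No evidence at hand speaks to the origin of this fall.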